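The compounds below may be only part of what the source reports. "The series", "measured", "known", "first", "only" and "open" are said of these compounds alone.

Measured in a functional assay on MCF7 cells (Homo sapiens) for antiproliferative activity, read by sulforhodamine B assay, with a stated time of 3 days; a higher number here means that more compound is needed for the effect, a lower number that less compound is needed:
- compound 1 `CCCC1=C(OCCC(C)C)C(CCC)(CCC)C(=O)/C(=C(O)\C=C\c2ccccc2)C1=O`: 9.1 uM
- compound 2 `COC1=C(CC(C)C)C(=O)/C(=C(O)/C=C/c2ccccc2)C(=O)C1(CC(C)C)CC(C)C`: 3.7 uM
- compound 3 `CCCC1(CC=C(C)C)C(=O)C(C(=O)/C=C/c2ccccc2)=C(O)C(CCC)(CCC)C1=O`: 5.8 uM

Compound 1 stands at the upper end of this small set. It lies within the scatter of compound 3, while compound 2 lies beyond the scatter with a lower number.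

Compound 4 `CCCCOC1=C(CCC)C(=O)/C(=C(O)/C=C/c2ccccc2)C(=O)C1(CCC)CCC` differs from compound 1 in one place: hydrogen in place of methyl on a saturated chain carbon bound to two saturated chain carbons. This puts hydrogen in place of methyl on a saturated chain carbon bound to two saturated chain carbons, so isopentyl becomes butyl.

Within the data shown here, no measured pair shows this change alone. The expectation therefore rests on the narrow spread from compound 2 at 3.7 uM to compound 1 at 9.1 uM, and no step beyond the scatter is expected in this assay. The expected change is a 1.3-fold lower number from compound 1 to compound 4 (0.11 log units; within the scatter). Compound 4 is estimated at 7 uM, with an expected range of 3.5 uM to 14 uM.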

Compound 4, concentration for half-maximal effect: 5.3 uM
Estimate against measurement, compound 4: 1.3-fold (0.12 log units) above; the measured number falls inside the stated range.
By their numbers in this assay, from the lowest: compounds 2, 4, 3 and 1 (each within the scatter of the next, the first and the last beyond it).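

In this assay, the change from isopentyl to butyl gives a 1.7-fold lower number from compound 1 to compound 4 (0.23 log units; within the scatter). Among these compounds, this is the first comparison in one place, and it shows that this methyl can go without a step beyond the scatter, which the earlier compounds, differing in several places, could not show. No other measurement here bears on the reason for this result.

The compounds shown leave open whether a longer chain at this place, or a chain ending in an amine or a carboxylic acid, would give a step beyond the scatter. They also leave open whether the same change reads alike with other chains on the shared core.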